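From Trifluoromethyl to Imidazolyl on the Phenyl Hydrazone

A few compounds are considered here, and "the series" means these few. Any claim that something is new, unique, unknown or untested is made for them only; others in the source may bear on it.

Going by the values given here, compound 2 `Nc1nc(N/N=C/c2ccc(C(F)(F)F)cc2)nc2c1ncn2[C@@H]1O[C@H](CO)[C@@H](O)[C@H]1O` is the only compound here with a numerical reading: in an assay on CHO-K1 cells for displacement of a labelled ligand from adenosine receptor A1 (Homo sapiens), read by scintillation counting, with a stated time of 60 min (a higher number here means a weaker inhibitor, a lower number a stronger inhibitor), compound 2 gives 37 nM. Compound 1 `CSCC/C=N/Nc1nc(N)c2ncn([C@@H]3O[C@H](CO)[C@@H](O)[C@H]3O)c2n1` reaches only the limit of this assay, giving > 10000 nM. Among the compounds with values here, the one measured step, an at least 270-fold lower number from compound 1 to compound 2 (2.43 log units; beyond the scatter), shows that the group on the carbon with a double bond to nitrogen matters greatly, though it compares 2-(methylsulfanyl)ethyl with 4-(trifluoromethyl)phenyl rather than two different phenyl substituents. Compound 3 `Nc1nc(N/N=C/c2ccc(-n3ccnc3)cc2)nc2c1ncn2[C@@H]1O[C@H](CO)[C@@H](O)[C@H]1O` differs from compound 2 by 1H-imidazol-1-yl in place of trifluoromethyl on an aromatic carbon. Within the data shown here, with no measured step addressing this change, the expected step of a 2.2-fold higher number from compound 2 to compound 3 (0.33 log units; beyond the scatter) is modest and uncertain. Compound 3 is estimated at 80 nM, within 20 nM to 400 nM.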

Compound 3, inhibition constant: > 10000 nM
Compound 3: no number, only a limit; the forecaster's own chance of this, stated with the estimate: 5%; middle value at least 120-fold (2.09 log units) from the limit.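

A phenyl ring on the carbon with a double bond to nitrogen is not enough on its own: compound 2 and compound 3 both carry one, yet 1H-imidazol-1-yl in place of trifluoromethyl gives an at least 270-fold higher number from compound 2 to compound 3 (2.43 log units; beyond the scatter). Compound 1 had pointed only to the group on that carbon, whereas this result shows that the substituent on the ring also matters greatly. The step between compound 1 and compound 3 cannot be read, as both values are limits and not numbers: the limit of > 10000 nM in this assay, at which 2 of the 3 values shown sit.

Going by these compounds, whether a chlorine, a methoxy or an amine at this place would keep a number close to that of compound 2 remains open. Going by these compounds alone, with only two groups compared on this ring, what separates them is also unknown.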